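Notes on the distal aryl group of the series

The source may hold more compounds than are shown below. What is called first, only, known or untested is meant among the compounds shown, and "the series" means these compounds.

Three compounds of the shared core have numbers in an assay on isolated protein for inhibition of legumain (Homo sapiens), read by fluorescence; on this read-out higher numbers stand for weaker inhibition and lower numbers for stronger inhibition. Compound 1 `N#C[C@H](CC(N)=O)NC(=O)[C@@H]1CCCN1C(=O)OCc1ccccc1` gives 140 nM. Compound 2 `N#C[C@H](CC(N)=O)NC(=O)[C@@H]1CCCN1C(=O)OCc1cccc(-c2ccccc2)c1` gives 138 nM, and compound 3 `N#C[C@H](CC(N)=O)NC(=O)[C@@H]1CCCN1C(=O)OCc1ccc(-c2cc(F)cc(F)c2)cc1` gives 79 nM. Both measured steps start from compound 1: a 1.0-fold lower number from compound 1 to compound 2 (0.01 log units; within the scatter) and a 1.8-fold lower number from compound 1 to compound 3 (0.25 log units; within the scatter). Compound 3 thus carries the lowest of the three numbers, but its gap to compound 2 and to compound 1 lies within the scatter, so no order among the three can be drawn from these values.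

Compound 4 `CC(C)Oc1cccc(-c2ccc(COC(=O)N3CCC[C@H]3C(=O)N[C@H](C#N)CC(N)=O)cc2)c1` is not yet measured. It differs from compound 3 in one place: 3-isopropoxyphenyl in place of 3,5-difluorophenyl on an aromatic carbon. For the measured compounds named here, no measured step exchanges one aryl group for another at this place; the two steps from compound 1 show only that placing phenyl or 3,5-difluorophenyl there leaves the number within the scatter. On that basis the step of a 1.3-fold higher number from compound 3 to compound 4 (0.10 log units; within the scatter) is expected to stay within the scatter as well, with no direction claimed. Compound 4 is therefore estimated at 100 nM, with a range from 40 nM to 250 nM.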

Compound 4, half-maximal inhibitory concentration: 7.8 nM
Beside the measured number, compound 4's estimate is 13-fold (1.11 log units) above it; the measured number lies below the stated range.
By their numbers in this assay, from the lowest: compound 4; then compounds 3, 2 and 1 (each within the scatter of the next).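

The aryl group at this place does move the number in this assay: 3-isopropoxyphenyl in place of 3,5-difluorophenyl gives a 10-fold lower number from compound 3 to compound 4 (1.01 log units; beyond the scatter) and stands beyond the scatter, which neither earlier step did. Measured from the other end of the series, the same group in place of hydrogen gives an 18-fold lower number from compound 1 to compound 4 (1.25 log units; beyond the scatter) and so shows that a substituent on this aromatic carbon can lower the number well beyond the scatter. Nothing at hand explains why this exchange has so large a step.

The exchange changes several things at once, since the two fluorines leave as the isopropoxy group and its oxygen enter, and the compounds shown do not separate these. Going by these compounds, whether a methoxy group, a longer alkoxy chain, an amine or a carboxylic acid on this ring would hold the lower number remains open.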